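This account rests on a few compounds, and the source may have more. Where it says the series, first, only, none or still open, it means among the compounds named here.

The three compounds measured so far, with their readings in a physicochemical assay for solubility, read by turbidimetry, in phosphate buffer, with a stated time of 24 h, at pH 7.4; on this read-out higher numbers stand for higher solubility and lower numbers for lower solubility:

compound 1 `CCNC(=O)Nc1nc2cc(-c3cnc(N4CCC(C)(C(=O)O)CC4)nc3)cc(-c3ccccn3)c2s1` — > 800 ug/mL, a limit of the assay rather than a number
compound 2 `CCNC(=O)Nc1nc2cc(-c3cnc(N4CCC(C)(C(=O)O)CC4)cn3)cc(-c3ccccn3)c2s1` — > 800 ug/mL, again a limit
compound 3 `CCNC(=O)Nc1nc2cc(-c3cncc(N4CCC(C)(C(=O)O)CC4)c3)cc(-c3ccccn3)c2s1` — > 800 ug/mL, again a limit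

Compound 1 therefore does not stand at a measured point at all: its reading sits at the limit of > 800 ug/mL in this assay, at which 3 of the 3 values shown sit, and the readings of compound 2 and compound 3 sit there as well. Among the compounds with values here, nothing in these three readings separates one compound from another, so no compound can be called more or less soluble than the rest.

Compound 4 `CCNC(=O)Nc1nc2cc(-c3cnc(N4CCCCC4(C)C(=O)O)nc3)cc(-c3ccccn3)c2s1` shares the core of compound 1 and differs from it only in one place: 2-carboxy-2-methylpiperidin-1-yl in place of 4-carboxy-4-methylpiperidin-1-yl on an aromatic carbon. Since the two compounds have the same atoms joined differently, and since the carboxylic acid and the methyl are kept, the change is a rearrangement within the piperidine ring rather than the loss or gain of any group.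

Within the data shown here, no measured step between two compounds is available here, so the expectation for compound 4 rests on where compound 1 stands. With compound 1 at > 800 ug/mL, the step from compound 1 to compound 4 is expected to be a number no higher from compound 1 to compound 4 (the limit leaves the size open), that is, nothing beyond the usual scatter. Compound 4 is thus estimated at 800 ug/mL, with a range from 350 ug/mL to 800 ug/mL, and most likely it will again return only a limit.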

Compound 4, solubility: 6.25 ug/mL
Compound 4: middle estimate off by 130-fold (2.11 log units), on the high side; the whole stated range lies above it.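

In this assay, 2-carboxy-2-methylpiperidin-1-yl in place of 4-carboxy-4-methylpiperidin-1-yl on the aromatic carbon gives an at least 120-fold lower number from compound 1 to compound 4 (2.10 log units; beyond the scatter). The two groups have the same atoms, the same ring and the same counts of hydrogen-bond donors and acceptors, so those counts cannot tell these two readings apart, and a change in how the atoms of the piperidine ring are joined is enough to produce a large step. Compound 4 also gives the first reading in this set that is a number and not a limit, while the others stay at the top of the assay's range: the limit of > 800 ug/mL in this assay, at which 3 of the 4 values shown sit.

These readings do not explain the step, and they do not show whether the same rearrangement on the cores of compound 2 and compound 3 would lead to a similar reading. Going by these compounds, it also remains open whether 2-carboxypiperidin-1-yl, which lacks the methyl, or a piperidine carrying an amine in place of the carboxylic acid would read close to compound 4 or stay at the limit.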